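The compounds below may be only part of what the source reports. "The series", "measured", "known", "first", "only" and "open" are said of these compounds alone.

Compound 1 `O=C(NCCCNc1nc(Nc2cccc(F)c2)ncc1C1CC1)C1CCC1` gives 8 nM in an assay on isolated protein for inhibition of serine/threonine-protein kinase TBK1 (Homo sapiens); on this read-out higher numbers stand for weaker inhibition and lower numbers for stronger inhibition. Compound 2 `CN(C)Cc1ccc(Nc2ncc(C3CC3)c(NCCCNC(=O)C3CCC3)n2)cc1` gives 6 nM.

Compound 2 and compound 1 lie within the scatter of each other, as the step of a 1.3-fold lower number from compound 1 to compound 2 (0.12 log units; within the scatter) shows. Compound 3 `CN1CCC(c2ccc(Nc3ncc(C4CC4)c(NCCCNC(=O)C4CCC4)n3)cc2)CC1` differs from compound 2 in one place: 1-methylpiperidin-4-yl in place of (dimethylamino)methyl on an aromatic carbon. For the measured compounds named here, the one measured step, from compound 1 to compound 2, also swapped the group on that ring and moved the number by little, so no step beyond the scatter is expected from no change at the digits printed from compound 2 to compound 3 (within the scatter). Compound 3 is therefore estimated at 6 nM, with a likely range from 2 nM to 18 nM.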

Compound 3, half-maximal inhibitory concentration: 8 nM
Compound 3: the middle estimate sits 1.3-fold (0.12 log units) below what was measured, and the stated range covers the measured number.
By their numbers in this assay, from the lowest: compounds 2, 1 and 3 (each within the scatter of the next).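

In this assay, the ring-bearing 1-methylpiperidin-4-yl, with 7 heavy atoms, takes the place of the open (dimethylamino)methyl, with 4, with a 1.3-fold higher number from compound 2 to compound 3 (0.12 log units; within the scatter). At this aromatic carbon, then, a six-membered non-aromatic ring with 1 hetero atom leaves the number within the scatter, which the earlier swap of 3-fluorophenyl did not show. No supporting measurement explains this result. Both groups compared here carry one nitrogen, so the compounds shown leave open whether a carboxylic acid or a methoxy group on this carbon would keep the number within the scatter.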